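This account rests on a few compounds, and the source may have more. Where it says the series, first, only, none or still open, it means among the compounds named here.

Compound 1 `CCc1nccn1CCC(C(N)=O)(c1ccccc1)c1ccccc1` gives 78.1 nM in an assay on ileum with muscarinic acetylcholine receptor M3 (Cavia porcellus) as the target; a lower number here means a stronger inhibitor, a higher number a weaker inhibitor.
Compound 2 `CC(C)(C)c1nccn1CCC(C(N)=O)(c1ccccc1)c1ccccc1` gives 30.2 nM in this assay.

Compound 2 has the lowest number of the two measured, and compound 1 is its nearest neighbour. Among the measured compounds shown here, the single measured step, a 2.6-fold lower number from compound 1 to compound 2 (0.41 log units; beyond the scatter), changed only the alkyl group on an aromatic carbon of the shared core. Compound 3 `NC(=O)C(CCn1cnc2ccccc21)(c1ccccc1)c1ccccc1` differs from compound 2 by 1H-benzimidazol-1-yl in place of 2-(tert-butyl)-1H-imidazol-1-yl on a saturated chain carbon, three bonds along the chain from two aromatic carbons and a carbonyl carbon. This is a change of another kind, so that one step is only a loose guide. For compound 3 a modest rise is expected, a 2.0-fold higher number from compound 2 to compound 3 (0.30 log units; within the scatter), with an estimate of 60 nM and a range from 20 nM to 200 nM.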

Compound 3, antagonist equilibrium constant: 2130 nM
For compound 3 the middle estimate is 36-fold (1.55 log units) below the measured one; measured number above the stated range.
By their numbers in this assay, from the lowest: compound 2; then compound 1; then compound 3.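

Putting 1H-benzimidazol-1-yl in place of 2-(tert-butyl)-1H-imidazol-1-yl gives a 71-fold higher number from compound 2 to compound 3 (1.85 log units; beyond the scatter), and putting it in place of 2-ethyl-1H-imidazol-1-yl gives a 27-fold higher number from compound 1 to compound 3 (1.44 log units; beyond the scatter). Since 1H-benzimidazol-1-yl and 2-(tert-butyl)-1H-imidazol-1-yl have matching counts of heavy atoms, hydrogen-bond donors and acceptors, those counts alone do not predict the number at this position. No measurement here explains the rise.

Still open, from the compounds shown here alone, is whether the rise follows from gaining the six-membered aromatic ring of carbon only or from losing the alkyl group. A 2-(tert-butyl)-1H-benzimidazol-1-yl group, which has both, could separate the two.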